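This account rests on a few compounds, and the source may have more. Where it says the series, first, only, none or still open, it means among the compounds named here.

Three compounds share one core and differ only in the group on the sulfonyl sulfur. In an assay on HeLa cells for binding affinity to 5-hydroxytryptamine receptor 6 (Homo sapiens) (a higher number here means a weaker inhibitor, a lower number a stronger inhibitor), compound 1 `COc1ccc(NS(=O)(=O)c2cccc([N+](=O)[O-])c2)cc1N1CCN(C)CC1` gives 79.4 nM. Compound 2 `COc1ccc(NS(=O)(=O)c2ccc(Br)cc2)cc1N1CCN(C)CC1` gives 5.01 nM, and compound 3 `COc1ccc(NS(=O)(=O)c2cc(Cl)cc(Cl)c2)cc1N1CCN(C)CC1` gives 2 nM, the lowest of the three numbers; the change a 40-fold lower number from compound 1 to compound 3 (1.60 log units; beyond the scatter) is large, a 16-fold lower number from compound 1 to compound 2 (1.20 log units; beyond the scatter) is large as well, and a 2.5-fold lower number from compound 2 to compound 3 (0.40 log units; beyond the scatter) is modest. Compound 4 `COc1ccc(NS(=O)(=O)c2ccccc2)cc1N1CCN(C)CC1` differs from compound 3 by one change: phenyl in place of 3,5-dichlorophenyl on a sulfonyl sulfur. Among the compounds with values here, no measured step removes both chlorines from this ring, so the step can only be judged from the three numbers at hand, where phenyl has no direct counterpart. Since compound 2 with 5.01 nM and compound 3 with 2 nM lie close while compound 1 with 79.4 nM lies far off, a modest weakening is expected for compound 4, a step of a 6.0-fold higher number from compound 3 to compound 4 (0.78 log units; beyond the scatter) in this assay. Compound 4 is therefore estimated at 12 nM, with a range of 4 nM to 40 nM.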

Compound 4, inhibition constant: 10 nM
The estimate for compound 4 lay 1.2-fold (0.08 log units) above the measured number; the range from low to high includes it.
By their numbers in this assay, from the lowest: compound 3; then compounds 2 and 4 (each within the scatter of the next); then compound 1.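

In this assay, phenyl on the sulfonyl sulfur shows what the two chlorines of 3,5-dichlorophenyl contribute: their loss is a modest step, a 5.0-fold higher number from compound 3 to compound 4 (0.70 log units; beyond the scatter) in size. Bromo and hydrogen on the aromatic carbon cannot be told apart, with a 2.0-fold higher number from compound 2 to compound 4 (0.30 log units; within the scatter) as the printed step, while hydrogen in place of nitro gives a 7.9-fold lower number from compound 1 to compound 4 (0.90 log units; beyond the scatter) as its step, so among these compounds the nitro of compound 1 stands apart from phenyl, whereas bromo does not. Nothing available here accounts for either step.

On these data alone, whether a single chlorine would give part or all of the step between compound 4 and compound 3 remains open. So does what an amine or a carboxylic acid on this ring would do.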